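A Quinoxaline Sulfonamide Joins Three Coumarin Enaminones

A few compounds are considered here, and "the series" means these few. Any claim that something is new, unique, unknown or untested is made for them only; others in the source may bear on it.

Compound 3 `O=C(/C=C\Nc1ccc(S(=O)(=O)Nc2ccc3cn[nH]c3c2)cc1)c1cc2ccccc2oc1=O` is one of three sulfonamides built on a shared core, each differing from the others only in the group on the sulfonamide nitrogen. In a functional assay on T47D cells (Homo sapiens) for cytotoxicity, read by sulforhodamine B assay, with a stated time of 48 h (on this read-out higher numbers stand for weaker inhibition and lower numbers for stronger inhibition), compound 3 gives 96500 nM, the highest of the three numbers, though all three sit within the scatter of one another: compound 1 `N=C(N)NS(=O)(=O)c1ccc(N/C=C\C(=O)c2cc3ccccc3oc2=O)cc1` gives 87600 nM and compound 2 `O=C(/C=C\Nc1ccc(S(=O)(=O)Nc2ncccn2)cc1)c1cc2ccccc2oc1=O` gives 75200 nM. The steps between them, a 1.1-fold higher number from compound 1 to compound 3 (0.04 log units; within the scatter) and a 1.3-fold higher number from compound 2 to compound 3 (0.11 log units; within the scatter), and likewise a 1.2-fold lower number from compound 1 to compound 2 (0.07 log units; within the scatter), all stay inside the scatter, so on these data the group on the sulfonamide nitrogen has not moved the read-out in any direction that can be trusted.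

Compound 4 `O=C(/C=C\Nc1ccc(S(=O)(=O)Nc2cnc3ccccc3n2)cc1)c1cc2ccccc2oc1=O` changes the same position once more: quinoxalin-2-yl in place of 1H-indazol-6-yl on a sulfonamide nitrogen. The three measured steps bear directly on this change, since each of them also swaps the group on the sulfonamide nitrogen, and none of them went beyond the scatter. The expectation for compound 4 is therefore a step no larger than the scatter, with no preferred direction, as a 1.1-fold lower number from compound 3 to compound 4 (0.06 log units; within the scatter). Compound 4 is accordingly estimated at 85000 nM in this assay, with a range from 40000 nM to 180000 nM.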

Compound 4, half-maximal inhibitory concentration: 86900 nM
The estimate for compound 4 lay 1.0-fold (0.01 log units) below the measured number; low and high end bracket the measured number.
By their numbers in this assay, from the lowest: compounds 2, 4, 1 and 3 (each within the scatter of the next).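

In this assay, the change from 1H-indazol-6-yl to quinoxalin-2-yl gives a 1.1-fold lower number from compound 3 to compound 4 (0.05 log units; within the scatter), while the comparisons with the other two groups give a 1.2-fold higher number from compound 2 to compound 4 (0.06 log units; within the scatter) and a 1.0-fold lower number from compound 1 to compound 4 (0.00 log units; within the scatter). Going by these compounds alone, the flat picture at the sulfonamide nitrogen therefore now holds for four groups, and it extends to a change the earlier compounds did not test: a group with 1 hydrogen-bond donor and a five-membered aromatic ring gives way to one with 0 hydrogen-bond donors, 2 hydrogen-bond acceptors and two six-membered aromatic rings, with no step beyond the scatter. No supporting evidence is available to explain why these groups give such closely matched numbers.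

The four compounds shown leave open whether a group of another kind on the sulfonamide nitrogen, such as a carboxylic acid, an amine or a longer alkyl chain, would produce a step beyond the scatter. All four also keep the shared core, so they cannot tell whether a change there would move the number in this assay.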